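Shortening the Bromoalkyl Chain of Compound 2

The compounds below may be only part of what the source reports. "The series", "measured", "known", "first", "only" and "open" are said of these compounds alone.

Compound 1 `[N-]=[N+]=NCCCCc1ccc(-c2ccc(-c3cccs3)s2)s1`: > 200000 nM (a limit)
Compound 2 `BrCCCCc1ccc(-c2ccc(-c3cccs3)s2)s1`: 23800 nM
Compound 3 `BrCCCc1ccc(-c2ccc(-c3cccs3)s2)s1`: not yet measured

Among the compounds with values here, in an ADME assay on MDCK cells (Canis lupus familiaris) for cytotoxicity, read by MTT assay, with a stated time of 2 days (on this read-out higher numbers stand for lower toxicity in this test and lower numbers for higher toxicity in this test), compound 2 gives 23800 nM, the only actual number so far. Compound 1 is reported only as a limit, > 200000 nM.

The structural change to compound 3 is bromo in place of bromomethyl on a saturated chain carbon, three bonds along the chain from an aromatic carbon, which amounts to 4-bromobutyl to 3-bromopropyl. Within the data shown here, the one measured step, an at least 8.4-fold lower number from compound 1 to compound 2 (0.92 log units; beyond the scatter), exchanged azido for bromo on the chain and did not alter the chain itself. Among the measured compounds shown here, it therefore bears only indirectly on this change, and no measured step covers it. No step beyond the scatter is expected in this assay, so the expectation stays anchored on compound 2 at 23800 nM. The expected step is a 1.0-fold lower number from compound 2 to compound 3 (0.01 log units; within the scatter). For compound 3 the estimated value is 23000 nM, with an expected range of 8000 nM to 70000 nM.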

Compound 3, half-maximal cytotoxic concentration: 35300 nM
Beside the measured number, compound 3's estimate is 1.5-fold (0.19 log units) below it; the measured number falls inside the stated range.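

In this assay, the change from 4-bromobutyl to 3-bromopropyl gives a 1.5-fold higher number from compound 2 to compound 3 (0.17 log units; within the scatter), so the two bromoalkyl chains cannot be told apart in this test. Within the data shown here, this is the first reading on the length of the chain itself, whereas the earlier step concerned only the group at its end. The other new step, an at least 5.6-fold lower number from compound 1 to compound 3 (0.75 log units; beyond the scatter), lies beyond the scatter, but compound 1 is given only as a limit, so this step has an open end: the limit of > 200000 nM in this assay, at which 1 of the 3 values shown sits.

As far as these compounds go, whether this holds for 2-bromoethyl or bromomethyl, or for a longer chain such as 5-bromopentyl, stays open. So does whether an amine or a carboxylic acid at the chain end would read like the bromo compounds or like compound 1.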